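The compounds below may be only part of what the source reports. "The series", "measured", "known", "first", "only" and "open" are said of these compounds alone.

Measured so far:
compound 1, `COc1cc(Br)cc(/C=C/C(=O)c2ccc(C)cc2)c1O`, 61.5%
compound 2, `Cc1ccc(C(=O)/C=C/c2cc(Br)ccc2O)cc1`, 31.8%
compound 3, `COc1cccc(C(=O)CC2C(C#N)=C(N)Oc3c(OC)cc(Br)cc32)c1`, 33.9%

All three were tested in a functional assay on MCF7 cells (Homo sapiens) for antiproliferative activity, read by sulforhodamine B assay, with a stated time of 72 h, tested at 30 uM; a lower number here means a stronger effect, a higher number a weaker effect of the compound at the concentration tested. Compound 1 and compound 2 share a core and differ in one place: hydrogen in place of methoxy on an aromatic carbon. That change made a step of a number 29.7 percentage points lower from compound 1 to compound 2 (beyond the scatter). Compound 3 has a different core; the difference between the two cores is not broken down here. In this assay compound 3 gives 33.9%, and compound 2 gives 31.8%, so the two stand within the scatter of each other.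

Compound 4, `COc1cccc(C(=O)CC2C(C#N)=C(N)Oc3ccc(Br)cc32)c1`, is not yet measured. It differs from compound 3 in one place: hydrogen in place of methoxy on an aromatic carbon. Among the compounds with values here, this is the same kind of change as the one from compound 1 to compound 2, but the surroundings differ: in compound 1 the methoxy sat ortho to a hydroxy group and meta to a large group, whereas in compound 3 it sits ortho to a fused ring and meta to a fused ring. Because the earlier step of a number 29.7 percentage points lower from compound 1 to compound 2 (beyond the scatter) was made on another core, only part of it is expected to carry over, and the expected step is a number 11.9 percentage points lower from compound 3 to compound 4 (beyond the scatter). Compound 4 is therefore estimated at 22%, within a range from 5% to 45%.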

Compound 4, a percentage reported as activity, at one concentration (the size of the read-out at that concentration, not a potency): 34.4%
The estimate for compound 4 lay 12.4 percentage points below the measured number; low and high end bracket the measured number.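

In this assay, putting hydrogen in place of methoxy on the core of compound 3 gave a number 0.5 percentage points higher from compound 3 to compound 4 (within the scatter), so on this core the swap had no effect that can be told from the scatter. The same swap therefore did not behave alike on the two cores: the same change on two cores in this assay, a number 29.7 percentage points lower (beyond the scatter) from compound 1 to compound 2 and a number 0.5 percentage points higher (within the scatter) from compound 3 to compound 4, 30.2 percentage points apart, beyond the scatter of two such steps This shows that a step seen on one core cannot simply be transferred to the other in this series, but it does not show which feature of the cores or of the surroundings of the methoxy group accounts for the gap, and one pair on each core gives no rule for any further core.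

The compounds shown leave open whether the core of compound 3 would respond to other groups at this place, such as a carboxylic acid or a longer ether chain like ethoxy. Each read-out gives only the size of the effect at a single concentration, and the data leave open whether the effects of these compounds would compare in the same way at other concentrations.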